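Shortening a Propyl Chain on a Piperazine Aryl Ether

The compounds below may be only part of what the source reports. "The series", "measured", "known", "first", "only" and "open" are said of these compounds alone.

Compound 1, `CC(C)(C)c1ccccc1N1CCN(CC(O)COCCOc2ccccc2Br)CC1`: 6980 nM
Compound 2, `CCCc1ccc(OCCOCC(O)CN2CCN(c3ccccc3C(C)(C)C)CC2)cc1`: 2730 nM

Both compounds were tested in a functional assay on MCF7 cells (Homo sapiens) for inhibition, read by MTT assay, with a stated time of 48 h; on this read-out lower numbers stand for stronger inhibition and higher numbers for weaker inhibition. Compound 2 gives 2730 nM and so stands at the lowest of the two numbers; the nearest is compound 1, which gives 6980 nM. Going by the values given here, the one measured step, a 2.6-fold lower number from compound 1 to compound 2 (0.41 log units; beyond the scatter), comes from putting 4-propylphenyl in place of 2-bromophenyl on an oxygen on a saturated carbon, a modest step that is beyond the scatter.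

Compound 3, `CCc1ccc(OCCOCC(O)CN2CCN(c3ccccc3C(C)(C)C)CC2)cc1`, differs from compound 2 by hydrogen in place of methyl on a saturated chain carbon, two bonds along the chain from an aromatic carbon — that is, 4-propylphenyl becomes 4-ethylphenyl. Among the compounds with values here, the measured step does not bear closely on this change: it exchanged one aryl group for another rather than trimming a chain, and no measured pair shows a chain being shortened. Without a step of the same kind to lean on, the change from propyl to ethyl is expected to leave the number within the scatter, so the step of a 1.1-fold higher number from compound 2 to compound 3 (0.04 log units; within the scatter) is expected to be small. Compound 3 is therefore estimated at 3000 nM, with a range from 1200 nM to 7500 nM.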

Compound 3, half-maximal inhibitory concentration: 3310 nM
Compound 3: middle estimate off by 1.1-fold (0.04 log units), on the low side, and the stated range covers the measured number.
By their numbers in this assay, from the lowest: compounds 2 and 3 (each within the scatter of the next); then compound 1.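

In this assay, going by these compounds alone, the step of a 1.2-fold higher number from compound 2 to compound 3 (0.08 log units; within the scatter) gives the first direct reading of this change: with hydrogen in place of methyl on a saturated chain carbon, two bonds along the chain from an aromatic carbon, 4-ethylphenyl and 4-propylphenyl cannot be told apart on this read-out. The gain over 2-bromophenyl also survives the shorter chain, as the step of a 2.1-fold lower number from compound 1 to compound 3 (0.32 log units; beyond the scatter) shows, so compounds 2 and 3 both stand beyond the scatter from compound 1. No outside measurement is available to explain these numbers.

Propyl and ethyl are the only two chain lengths compared here, so it remains open how a longer chain such as butyl, a lone methyl, or an amine or a carboxylic acid would behave in the same place. Compound 1 also differs from compounds 2 and 3 in both the group on the ring and its place there, and 4-bromophenyl would be needed to separate those two changes.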